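The compounds below may be only part of what the source reports. "The series", "measured", "known", "first", "only" and "open" are said of these compounds alone.

Measured compounds: compound 1 `CCCCCCCCOC1CC(=O)Nc2c1c(C)nn2-c1ncnc2nc[nH]c12` with 8 nM; compound 2 `Cc1nn(-c2ncnc3nc[nH]c23)c2c1C(NC(=O)c1ccccc1)CC(=O)N2` with 3 nM.

In a functional assay on HEK293 cells for agonist activity at G-protein coupled receptor 39 (Homo sapiens), read by scintillation proximity assay and inositol phosphate accumulation, with a stated time of 75 min, in the presence of a further agent that is not named here (a lower number here means that less compound is needed, a higher number that more compound is needed for the effect), compound 2 gives 3 nM, the lower of the two numbers, and compound 1 gives 8 nM. Compound 3 `Cc1nn(-c2ncnc3nc[nH]c23)c2c1C(OCCn1cccn1)CC(=O)N2` differs from compound 2 by 2-(1H-pyrazol-1-yl)ethoxy in place of benzamido on a saturated ring carbon. For the measured compounds named here, the only step that bears on this change is a 2.7-fold lower number from compound 1 to compound 2 (0.43 log units; beyond the scatter), in which an ether on that saturated ring carbon was exchanged for benzamido. Compound 3 brings an ether back onto that carbon, so part of that gain is expected to be given back; the step is estimated as a 3.3-fold higher number from compound 2 to compound 3 (0.52 log units; beyond the scatter). Compound 3 is therefore expected at 10 nM, with a range from 3 nM to 40 nM.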

Compound 3, half-maximal effective concentration: 16 nM
Compound 3: the middle estimate sits 1.6-fold (0.20 log units) below what was measured; the measured number falls inside the stated range.
By their numbers in this assay, from the lowest: compound 2; then compounds 1 and 3 (each within the scatter of the next).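

In this assay, benzamido at this saturated ring carbon now stands apart from a second ether as well as from octyloxy, with a 5.3-fold higher number from compound 2 to compound 3 (0.73 log units; beyond the scatter). Between the two ethers, 1H-pyrazol-1-yl in place of hexyl on the chain gives a 2.0-fold higher number from compound 1 to compound 3 (0.30 log units; within the scatter), so this exchange does not separate them. Nothing available explains either step. Still open, going by these compounds, is whether the advantage of benzamido follows its amide or its six-membered aromatic ring; an acetamido group and a benzyloxy group on that carbon would separate the two.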